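Phenyl in place of hydrogen on a pyrazolopyridinone core

A few compounds are considered here, and "the series" means these few. Any claim that something is new, unique, unknown or untested is made for them only; others in the source may bear on it.

Measured compounds:
Compound 1 `Cc1cc2nn(-c3ccccc3)c(N)c2c(=O)[nH]1`: 5%
Compound 2 `COc1ccccc1-c1cc2nn(-c3ccccc3)c(N)c2c(=O)[nH]1`: 6%

In an assay on isolated protein for inhibition of MAP kinase-activated protein kinase 5 (Homo sapiens), read by mobility shift assay, tested at 30 uM (a lower number here means less inhibition, a higher number more inhibition at the concentration tested (going by the name of the read-out)), compound 1 gives 5%, the lowest of the two numbers, and compound 2 gives 6%, a value within the scatter of it. Compound 3 `Cc1[nH]c(=O)c2c(N)n(-c3ccccc3)nc2c1-c1ccccc1` differs from compound 1 by phenyl in place of hydrogen on an aromatic carbon. Within the data shown here, the only measured step that bears on it, a number 1 percentage points higher from compound 1 to compound 2 (within the scatter), changed a group on the same core without moving the number beyond the scatter. Compound 3 is therefore expected to show a number 1 percentage points higher from compound 1 to compound 3 (within the scatter), no step beyond the scatter. The estimate for compound 3 is 6%, ranging from -5% to 18%.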

Compound 3, a percentage reported as inhibition, at one concentration (the size of the read-out at that concentration, not a potency): 6%
Beside the measured number, compound 3's estimate shows no gap at the digits printed; low and high end bracket the measured number.
By their numbers in this assay, from the lowest: compounds 1, 2 and 3 (each within the scatter of the next).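

Putting phenyl in place of hydrogen on the aromatic carbon ortho to a methyl group gives, in this assay, a number 1 percentage points higher from compound 1 to compound 3 (within the scatter), so the added ring leaves the number within the scatter. The earlier compounds shown here showed only a change at the carbon that carries the methyl group, and this is a second place on the shared core where a large aromatic group changes nothing measurable. Nothing at hand explains this result. Going by these compounds, whether an amine, a carboxylic acid or a longer chain on this carbon would move the number beyond the scatter remains open.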